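Compound 4: 1,3-thiazol-2-yl in place of 1H-imidazol-1-yl

A few compounds are considered here, and "the series" means these few. Any claim that something is new, unique, unknown or untested is made for them only; others in the source may bear on it.

In an ADME assay on MT4 cells (Homo sapiens) for cytotoxicity (on this read-out lower numbers stand for higher toxicity in this test and higher numbers for lower toxicity in this test), three compounds with a shared core have been measured. Compound 1 (`COC(=O)N[C@H](C(=O)NN(CCC[C@@](O)(Cc1ccccc1)C(=O)N[C@H]1c2ccccc2C[C@H]1O)Cc1ccc(N(C)C)cc1)C(C)(C)C`) gives > 10000 nM, which is a limit of the assay. Compound 2 (`COC(=O)N[C@H](C(=O)NN(CCC[C@@](O)(Cc1ccccc1)C(=O)N[C@H]1c2ccccc2C[C@H]1O)CC(C)C)C(C)(C)C`) gives > 10000 nM, which is also a limit. Compound 3 (`COC(=O)N[C@H](C(=O)NN(CCC[C@@](O)(Cc1ccccc1)C(=O)N[C@H]1c2ccccc2C[C@H]1O)Cc1ccc(-n2ccnc2)cc1)C(C)(C)C`) gives > 10000 nM, again a limit and not a number. Going by the values given here, the series so far therefore shows (the limit of > 10000 nM in this assay, at which 3 of the 3 values shown sit).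

Compound 4 (`COC(=O)N[C@H](C(=O)NN(CCC[C@@](O)(Cc1ccccc1)C(=O)N[C@H]1c2ccccc2C[C@H]1O)Cc1ccc(-c2nccs2)cc1)C(C)(C)C`) carries 1,3-thiazol-2-yl in place of 1H-imidazol-1-yl on an aromatic carbon. The change at that same aromatic carbon was a step that the two limits leave unreadable from compound 1 to compound 3. The two exchanges further out were a step that the two limits leave unreadable from compound 1 to compound 2 and a step that the two limits leave unreadable from compound 2 to compound 3. None of these gives a size to carry over, so no step beyond the scatter is expected in this assay, and no direction can be named. The expected change is a step that the limit leaves unreadable from compound 3 to compound 4. Compound 4 is estimated at 15000 nM, with an expected range of 5000 nM to 50000 nM.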

Compound 4, half-maximal cytotoxic concentration: > 10000 nM
Compound 4: only a limit was reported; the forecaster's own chance of this, stated with the estimate: 80%; the middle value lies beyond the limit too.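

In this assay compound 4 gives > 10000 nM as a limit and not a number. None of the steps among compound 1, compound 2, compound 3 and compound 4 can be read. How far these compounds differ in this read-out stays open, since all sit at one limit: the limit of > 10000 nM in this assay, at which 4 of the 4 values shown sit.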